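From benzylamino to octylsulfanyl on the shared core

The source may hold more compounds than are shown below. What is called first, only, known or untested is meant among the compounds shown, and "the series" means these compounds.

In an ADME assay on BCBL1 cells (Homo sapiens) for cytotoxicity, with a stated time of 7 days (on this read-out higher numbers stand for lower toxicity in this test and lower numbers for higher toxicity in this test), compound 1 `CNc1nc(N)nc2c1ncn2/C=C1/CC1(CO)CO` gives 67000 nM and compound 3 `Nc1nc(NCc2ccccc2)c2ncn(/C=C3/CC3(CO)CO)c2n1` gives 19900 nM. Compound 2 `CN(C)c1nc(N)nc2c1ncn2/C=C1/CC1(CO)CO` gives > 20000 nM, which is a limit of the assay and not a number. Among the compounds with values here, compound 3 therefore holds the lowest of the two true numbers so far, while the limit leaves its place relative to compound 2 open.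

Compound 4 `CCCCCCCCSc1nc(N)nc2c1ncn2/C=C1/CC1(CO)CO` carries octylsulfanyl in place of benzylamino on an aromatic carbon. The new group has no ring and no hydrogen-bond donor, and sulfur replaces nitrogen at the point of attachment. Within the data shown here, no measured step makes that exchange, so the evidence is indirect.

Among the measured compounds shown here, only one step bearing on it can be read: a 3.4-fold lower number from compound 1 to compound 3 (0.53 log units; beyond the scatter), where phenyl replaced hydrogen on the saturated chain carbon. The other two are a step that the limit leaves unreadable from compound 1 to compound 2 and a number no higher from compound 2 to compound 3 (the limit leaves the size open), and neither gives a size. On that single modest step, a further modest fall in this assay is expected, though with wide uncertainty. The expected change is a 2.2-fold lower number from compound 3 to compound 4 (0.34 log units; beyond the scatter). Compound 4 is estimated at 9000 nM, with an expected range of 2500 nM to 30000 nM.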

Compound 4, half-maximal cytotoxic concentration: > 20000 nM
Compound 4 was reported as a limit; the forecaster's own chance of this, stated with the estimate: 10%; at least 2.2-fold (0.34 log units) between middle value and limit.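

In this assay, octylsulfanyl in place of benzylamino on this aromatic carbon gave a number no lower from compound 3 to compound 4 (the limit leaves the size open) and so did not carry the number further down, even though the new group has no ring and no hydrogen-bond donor and is attached through sulfur. Within the data shown here, until now the only readable fall at this position came with benzylamino, and the octylsulfanyl result adds no second example of one, while the steps to compound 4 from compound 1 and from compound 2 cannot be read. Compound 4 is reported as a limit of the assay, and compound 2 stands at the same limit: the limit of > 20000 nM in this assay, at which 2 of the 4 values shown sit.

As far as these compounds go, how far compound 4 actually lies from compound 3 remains open, and so does the question of which part of the exchange goes with the result: the ring, the nitrogen at the point of attachment, or the length of the chain. A benzylsulfanyl group on this carbon, which pairs the ring with sulfur, and an octylamino group, which pairs the chain with nitrogen, would pull those parts apart.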